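Urea series: cyano replaced by amino on the phenyl ring

The compounds below may be only part of what the source reports. "The series", "measured", "known", "first", "only" and "open" are said of these compounds alone.

Measured so far in an assay on isolated protein for inhibition of serine/threonine-protein kinase 10 (Homo sapiens), read by thermal shift assay, tested at 10 uM; a higher number here means that the compound stabilises the target more against heat, a lower number that the compound stabilises the target less:
- compound 1 `CC(C)(C)c1cc(NC(=O)Nc2ccc(Cl)cc2)n(-c2ccc(C(F)(F)F)cc2)n1`: -0.6 degrees C
- compound 2 `CC(C)(C)c1cc(NC(=O)Nc2ccc(Cl)cc2)n(-c2ccc(C#N)cc2)n1`: 2.2 degrees C

Among the compounds with values here, compound 2 gives the higher of the two numbers in this assay; the nearest is compound 1, and the only measured step, a number 2.8 degrees C higher from compound 1 to compound 2 (beyond the scatter), is beyond the scatter and modest in size. Compound 3 `CC(C)(C)c1cc(NC(=O)Nc2ccc(Cl)cc2)n(-c2ccc(N)cc2)n1` differs from compound 2 by amino in place of cyano on an aromatic carbon. Within the data shown here, the one measured step concerns the same position of the shared core, but exchanges a different pair of groups, so it bears on the new change only as a guide to scale: a single exchange at this position moved the melting temperature by a modest amount. Among the measured compounds shown here, no measured step involves an amino group, so the direction is open. A step of similar size or smaller is expected, which for compound 3 means an estimated a number 0.70 degrees C lower from compound 2 to compound 3 (within the scatter). Compound 3 is therefore estimated at 1.5 degrees C, in the range -0.5 degrees C to 3.5 degrees C.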

Compound 3, shift of the target's melting temperature: 2 degrees C
Estimate against measurement, compound 3: 0.50 degrees C below; measured number inside the range.
By their numbers in this assay, from the lowest: compound 1; then compounds 3 and 2 (each within the scatter of the next).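

In this assay, amino in place of cyano gives a number 0.20 degrees C lower from compound 2 to compound 3 (within the scatter), so this exchange at the position leaves no change that can be told from the scatter, even though the two groups differ in heavy atoms and hydrogen-bond donors as counted. Amino in place of trifluoromethyl gives a number 2.6 degrees C higher from compound 1 to compound 3 (beyond the scatter), close in size to a number 2.8 degrees C higher from compound 1 to compound 2 (beyond the scatter), so among these three compounds only compound 1 stands apart. No measurement on hand accounts for this result.

As far as these compounds go, whether the separation of compound 1 reflects something particular to trifluoromethyl remains open, as three groups at one position cannot settle it. Also open, from the compounds shown here alone, is how a carboxylic acid, a methoxy group or an acetamide would read at this position, and whether any group there would rise clearly above compounds 2 and 3.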